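Sulfonamide variation on a shared core: compound 3 to compound 4

A few compounds are considered here, and "the series" means these few. Any claim that something is new, unique, unknown or untested is made for them only; others in the source may bear on it.

Compound 1 `CCN(CC)CCNS(=O)(=O)c1ccc(-c2ccnc3[nH]ccc23)cc1`: 10000 nM
Compound 2 `CC(C)(C)OC(=O)NCCNS(=O)(=O)c1ccc(-c2ccnc3[nH]ccc23)cc1`: no result reported
Compound 3 `CN(CCO)S(=O)(=O)c1ccc(-c2ccnc3[nH]ccc23)cc1`: 2700 nM

In an assay on isolated protein for inhibition of serine/threonine-protein kinase Nek1 (Homo sapiens), read by TR-FRET, with a stated time of 30 min (on this read-out higher numbers stand for weaker inhibition and lower numbers for stronger inhibition), compound 1 gives 10000 nM and compound 3 gives 2700 nM; compound 2 carries no number. Compound 3 thus holds the lower of the two numbers, with a 3.7-fold lower number from compound 1 to compound 3 (0.57 log units; beyond the scatter) separating it from compound 1. Compound 4 `CC(C)(O)CNS(=O)(=O)c1ccc(-c2ccnc3[nH]ccc23)cc1` differs from compound 3 by (2-hydroxy-2-methylpropyl)amino in place of (2-hydroxyethyl)(methyl)amino on a sulfonyl sulfur. Going by the values given here, the sole measured step, from compound 1 to compound 3, also alters the group on the sulfonyl sulfur, but in a different manner, so it gives only a loose guide; no measured step exchanges one hydroxyalkylamino group for another. A shift within the scatter, or at most a modest one in either direction, is expected, a 1.1-fold higher number from compound 3 to compound 4 (0.05 log units; within the scatter). Compound 4 is estimated at 3000 nM, within 1000 nM to 9000 nM.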

Compound 4, half-maximal inhibitory concentration: 5800 nM
Beside the measured number, compound 4's estimate is 1.9-fold (0.29 log units) below it, and the stated range covers the measured number.
By their numbers in this assay, from the lowest: compound 3; then compounds 4 and 1 (each within the scatter of the next).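

Two hydroxyalkylamino groups on a sulfonyl sulfur are not interchangeable here: this assay shows a 2.1-fold higher number from compound 3 to compound 4 (0.33 log units; beyond the scatter) for (2-hydroxy-2-methylpropyl)amino in place of (2-hydroxyethyl)(methyl)amino. The other step reads a 1.7-fold lower number from compound 1 to compound 4 (0.24 log units; within the scatter) and so does not separate 1-hydroxy-1-methylethyl from (diethylamino)methyl on this saturated chain carbon. Nothing available explains either step.

On these data alone, the change to compound 4 alters the substitution on the sulfonamide nitrogen and the chain together, so which part carries the step remains open. Also open, as far as these compounds go, is how a piperidine or a carboxylic acid at this position would read.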